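The source may hold more compounds than are shown below. What is called first, only, known or untested is meant among the compounds shown, and "the series" means these compounds.

Measured so far:
Compound 1, `CCCCCCSc1ccn([C@@H]2O[C@H](COP(=O)(O)OP(=O)(O)O)[C@@H](O)[C@H]2O)c(=O)n1`, in an in vitro functional assay on 1321-N1 cells for agonist activity at P2Y purinoceptor 6 (Homo sapiens) (on this read-out lower numbers stand for an effect already at smaller amounts and higher numbers for an effect only at larger amounts of compound), gives 4900 nM.
Compound 2, `N[C@@H]1[C@H](O)[C@@H](COP(=O)(O)OP(=O)(O)O)O[C@H]1n1ccc(=O)[nH]c1=O`, in this assay gives 3900 nM.
Compound 3, `O=c1ccn([C@@H]2O[C@@]3(COP(=O)(O)OP(=O)(O)O)C[C@H]3[C@H]2O)c(=O)[nH]1`, in this assay gives 3500 nM.

Among these three, compound 1 carries the highest number, yet its nearest neighbour is compound 2 and its furthest is compound 3, and both of those gaps fall within the usual scatter of this read-out. So no order can be claimed among the three; they sit together in the low micromolar region of this assay, and none is the strongest or weakest on this evidence.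

The next compound, compound 4, `NC(=O)CSc1ccn([C@@H]2O[C@H](COP(=O)(O)OP(=O)(O)O)[C@@H](O)[C@H]2O)c(=O)n1`, follows from compound 1 by one change: carbamoyl in place of pentyl on a saturated chain carbon bound to a sulfur. Among the measured compounds shown here, no pair of measured compounds differs in a single place, so there is no measured step to set a scale for how far this change might move the number. The account therefore rests on the values themselves and on the change described.

With the hexylsulfanyl group of compound 1 traded for a (carbamoylmethyl)sulfanyl group, the expected step of a 1.3-fold higher number from compound 1 to compound 4 (0.12 log units; within the scatter) is small, at most a modest rise in the number, and could well stay within the scatter. On that basis compound 4 is estimated at 6500 nM in this assay, with a range from 2000 nM to 20000 nM.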

Compound 4, half-maximal effective concentration: 18000 nM
Compound 4: the middle estimate sits 2.8-fold (0.44 log units) below what was measured; the range from low to high includes it.
By their numbers in this assay, from the lowest: compounds 3, 2 and 1 (each within the scatter of the next); then compound 4.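

In this assay, among the compounds shown here, carbamoyl in place of pentyl on a saturated chain carbon bound to a sulfur gives a 3.7-fold higher number from compound 1 to compound 4 (0.57 log units; beyond the scatter), the first step in this set that compares two compounds differing in one place. It shows that the number does respond to what is carried at this place, modestly but beyond the scatter, and that the hexylsulfanyl group of compound 1 goes with the lower number of the pair, while compound 4, with its (carbamoylmethyl)sulfanyl group, still gives a measured value of 18000 nM in this read-out. Nothing available explains why the number moves this way.

Since hexyl gives way to carbamoylmethyl in a single step, the chain is shortened and the amide end is introduced together, so the pair cannot show which of the two accounts for the rise. The compounds shown also leave open how a plain methyl or a longer chain would fare on the sulfur, or whether a carboxylic acid or an amine in place of the carbamoyl would move the number further.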